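The compounds below may be only part of what the source reports. "The series", "measured", "known", "first", "only" and "open" are said of these compounds alone.

Going by the values given here, in a functional assay (blood) for inhibition, with Homo sapiens as the target (a lower number here means a stronger inhibitor, a higher number a weaker inhibitor), compound 2 `C/C(=N\OCCSc1nnnn1C)c1ccc(Sc2cc(F)cc(C3CCOCC3)c2)cc1` gives 120 nM, the lowest of the two numbers known, while compound 1 `COC1(c2cc(F)cc(Sc3ccc4c(c3)CC/C4=N\O)c2)CCOCC1` gives 290 nM, a gap beyond the usual scatter. Compound 3 `C/C(=N\OC(=O)N(C)C)c1ccc(Sc2cc(F)cc(C3CCOCC3)c2)cc1` has not yet been measured in this assay. It differs from compound 2 by dimethylcarbamoyl in place of 2-((1-methyl-1H-tetrazol-5-yl)sulfanyl)ethyl on an oxygen. Among the compounds with values here, no measured pair shows what such an exchange on that oxygen does, so the size of the step is open; the change is expected to be modest and, if anything, towards a higher number. Compound 3 is expected to give about 200 nM in this assay, within a range of 60 nM to 700 nM, an estimated step of a 1.7-fold higher number from compound 2 to compound 3 (0.22 log units; within the scatter).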

Compound 3, half-maximal inhibitory concentration: 2610 nM
Compound 3: the middle estimate sits 13-fold (1.12 log units) below what was measured; the measured number lies above the stated range.
By their numbers in this assay, from the lowest: compound 2; then compound 1; then compound 3.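

In this assay, the group on the oxygen whose other neighbour is the double-bonded nitrogen proves far from neutral: dimethylcarbamoyl in place of 2-((1-methyl-1H-tetrazol-5-yl)sulfanyl)ethyl gives a 22-fold higher number from compound 2 to compound 3 (1.34 log units; beyond the scatter) on the shared core. The earlier compounds shown here offered no pair that could show this. Nothing available bears on the reason for a step of this size.

Still open, as far as these compounds go, is whether the step follows from the tetrazole ring leaving, the chain leaving, or the carbamoyl entering. A plain methyl, an ethyl chain ending in an amine, or one ending in a carboxylic acid on that oxygen would help separate these.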